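A Methoxy Group Joins a Chloro-Bearing Quinolinone

The source may hold more compounds than are shown below. What is called first, only, known or untested is meant among the compounds shown, and "the series" means these compounds.

Measured so far:
Compound 1, `COc1ccc2[nH]c(=O)c(-c3nc4ccccc4[nH]3)cc2c1`: in a functional assay on HepG2 cells (Homo sapiens) for cytotoxicity, read by MTT assay, with a stated time of 48 h (a lower number here means a stronger inhibitor, a higher number a weaker inhibitor), compound 1 gives > 100000 nM, which is a limit of the assay and not a number.
Compound 2, `O=c1[nH]c2ccccc2cc1-c1nc2cc(Cl)ccc2[nH]1`: in this assay compound 2 gives 8450 nM.

Going by the values given here, compound 2 therefore holds the only real number in this small set. Compound 1 sits at the limit of > 100000 nM in this assay, at which 1 of the 2 values shown sits. Among the compounds with values here, the two measured compounds differ in two places, so their values show only that compound 1, which carries a methoxy but no chlorine, reaches no number, while compound 2 does.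

Compound 3, `COc1ccc2[nH]c(=O)c(-c3nc4cc(Cl)ccc4[nH]3)cc2c1`, keeps the chlorine of compound 2 and adds one change: methoxy in place of hydrogen on an aromatic carbon. No single-point comparison has been measured, so the size of this step can only be expected. It is expected to weaken inhibition modestly, by about a 2.4-fold higher number from compound 2 to compound 3 (0.37 log units; beyond the scatter) in this assay. Compound 3 is therefore estimated at 20000 nM, within a range from 6000 nM to 80000 nM.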

Compound 3, half-maximal inhibitory concentration: > 100000 nM
Compound 3: a limit, no number (the forecaster's own chance of this, stated with the estimate: 25%); middle value at least 5.0-fold (0.69 log units) away from the limit.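

With the chlorine kept, methoxy in place of hydrogen on this aromatic carbon gives an at least 11-fold higher number from compound 2 to compound 3 (1.07 log units; beyond the scatter), so this one change is enough to take the chloro compound from a real number to no number at all. In this assay compound 3 gives > 100000 nM, which is a limit of the assay and not a number. The chlorine alone therefore does not bring a methoxy-bearing compound to a number, and the chloro step from compound 1 to compound 3 cannot be read: the limit of > 100000 nM in this assay, at which 2 of the 3 values shown sit.

Going by these compounds, how far compound 3 lies beyond its limit stays unknown, and so does the full size of the methoxy step. Also open, on these data alone, is whether a different group on this same carbon, such as a hydroxyl, a fluorine or an amine, would keep a measurable value.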